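Adding a Fluorine at Two Different Places in One Series

The compounds below may be only part of what the source reports. "The series", "measured", "known", "first", "only" and "open" are said of these compounds alone.

In a functional assay on the whole organism for inhibition, with Mus musculus as the target, at a dose of 25 mg/kg by the oral route (on this read-out higher numbers stand for more inhibition at the one dose given (going by the name of the read-out) and lower numbers for less inhibition), compound 1 `c1ccc(N2CCN(CCCCOc3ccc4c(c3)CCC4)CC2)cc1` gives 75%. Compound 2 `c1ccc(N2CCN(CCCCCOc3ccc4c(c3)CCC4)CC2)cc1` gives 27% in this assay, and compound 3 `Fc1ccc(N2CCN(CCCCCOc3ccc4c(c3)CCC4)CC2)cc1` gives 58%. The difference between the cores of compound 1 and compound 2 is not broken down here. From compound 2 to compound 3 the change is fluoro in place of hydrogen on an aromatic carbon and the step is a number 31 percentage points higher from compound 2 to compound 3 (beyond the scatter). Compound 4 `Fc1cc2c(cc1OCCCCN1CCN(c3ccccc3)CC1)CCC2` is not yet measured; it differs from compound 1 by fluoro in place of hydrogen on an aromatic carbon. This is the same kind of change, but the place differs: in compound 4 the fluoro sits on a ring that is part of a fused or bridged system of two rings, ortho to a large group, meta to a fused ring and para to a fused ring, whereas in compound 3 it is para to a large group. The step from compound 1 to compound 4 in this assay is expected to be a number 5 percentage points higher from compound 1 to compound 4 (within the scatter), smaller than the earlier one, because compound 1 already gives 75%, a number that is high on this read-out. Compound 4 is expected to give 80%, between 60% and 95%.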

Compound 4, a percentage reported as inhibition, in the whole organism at one dose (the size of the read-out at that dose, not a potency): 33%
Estimate against measurement, compound 4: 47 percentage points above; the measured number lies below the stated range.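

In this assay, fluoro in place of hydrogen gives a step that is a number 42 percentage points lower from compound 1 to compound 4 (beyond the scatter). Set beside the earlier step, this change does not carry over from one core to another with the same result: the same change on two cores in this assay, a number 31 percentage points higher (beyond the scatter) from compound 2 to compound 3 and a number 42 percentage points lower (beyond the scatter) from compound 1 to compound 4, 73 percentage points apart, beyond the scatter of two such steps These steps do not show whether the core or the place of the fluoro decides the outcome, as the fluoro is para to a large group in compound 3 but ortho to a large group, meta to a fused ring and para to a fused ring in compound 4.

Still open, as far as these compounds go, is how fluoro would behave at the place it holds in compound 3 on the core of compound 1, and at the place it holds in compound 4 on the core of compound 2. Also open, from the compounds shown here alone, is whether a chloro or methoxy group at these places would follow fluoro.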